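Adding a methyl to the urea end of compound 3

This account rests on a few compounds, and the source may have more. Where it says the series, first, only, none or still open, it means among the compounds named here.

The three measured compounds share a core and differ at its two ends. Compound 1 `CC(=O)N1CCN(c2ccc(OCC3CCN(C(=O)OC(C)C)CC3)cn2)CC1` carries an acetyl on the ring nitrogen at one end. In a functional assay on CHO-K1 cells for agonist activity at Glucose-dependent insulinotropic receptor (Homo sapiens), read by a luciferase reporter, with a stated time of 5 h (on this read-out higher numbers stand for an effect only at larger amounts of compound and lower numbers for an effect already at smaller amounts), compound 1 gives only a limit, > 10000 nM, not a number. Compound 2 `CC(C)OC(=O)N1CCC(COc2ccc(N3CCN(S(=O)(=O)c4cccnc4)CC3)nc2)CC1` gives 2000 nM, and the step of an at least 5.0-fold lower number from compound 1 to compound 2 (0.69 log units; beyond the scatter) shows a clear gain. Compound 3 `CCCS(=O)(=O)N1CCN(c2ccc(OCC3CCN(C(=O)NC(C)C)CC3)cn2)CC1` gives 1000 nM; this number sits within the usual scatter of the value of compound 2, so the two cannot be told apart.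

Compound 4 `CCCS(=O)(=O)N1CCN(c2ccc(OCC3CCN(C(=O)NC(C)(C)C)CC3)cn2)CC1` differs from compound 3 by methyl in place of hydrogen on a saturated chain carbon bound to an amide-type nitrogen and two saturated chain carbons. Going by the values given here, the single measured step concerns the other end of the molecule, where acetyl became a sulfonyl, and so does not speak to a change on the carbamoyl side; compound 2 and compound 3 differ in more than one place, and their values only show that they sit close together. Among the compounds with values here, with no measured step touching this position, the expected step of no change at the digits printed from compound 3 to compound 4 (within the scatter) is none beyond the scatter. Compound 4 is therefore estimated at 1000 nM, with a likely range from 400 nM to 2500 nM.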

Compound 4, half-maximal effective concentration: 800 nM
Compound 4: middle estimate off by 1.3-fold (0.10 log units), on the high side; the measured number falls inside the stated range.
By their numbers in this assay, from the lowest: compounds 4, 3 and 2 (each within the scatter of the next, the first and the last beyond it). At a limit, above all of these: compound 1.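

Going by these compounds alone, this is the first measured step on the carbamoyl side of the molecule, since the earlier step concerned only the other end. In this assay, going from isopropylcarbamoyl to (tert-butyl)carbamoyl gives a 1.3-fold lower number from compound 3 to compound 4 (0.10 log units; within the scatter), so the two compounds cannot be told apart and this position accepts one more methyl without a visible loss of agonist activity. Nothing measured for these compounds gives a reason for this outcome.

The compounds shown leave open whether larger changes at this end would be accepted as well, such as a cyclohexyl or a phenyl on the urea nitrogen, or an amine or a carboxylic acid at the end of the chain. From the compounds shown here alone, it also remains open what the urea itself contributes, as compound 2 and compound 3 differ in more than one place, and a compound joining the propylsulfonyl group to the isopropyl carbamate would allow a comparison with a change in one place only.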